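Replacing Carbamoyl with 3-Aminopropyl on the Shared Core

This account rests on a few compounds, and the source may have more. Where it says the series, first, only, none or still open, it means among the compounds named here.

Compound 1 `NC(=O)C[C@H](NC(=O)CN(c1nc(Cl)nc2[nH]cnc12)C1CC1)C(=O)O` gives 20.1% in a functional assay on the whole organism (Tail, strain ICR) with Mus musculus as the target, in the tail flick test, with a stated time of 90 min, at a dose of 25 umol/kg by the oral route (on this read-out lower numbers stand for a weaker effect and higher numbers for a stronger effect at the one dose given), the lower of the two values known, though compound 2 `C[C@@H](O)[C@H](NC(=O)CN(c1ncnc2c1ncn2C1CCCCO1)C1CC1)C(=O)OCc1ccccc1`, which gives 23.4% in this assay, lies within the scatter of compound 1, so the two cannot be told apart. Compound 3 `NCCCC[C@H](NC(=O)CN(c1nc(Cl)nc2[nH]cnc12)C1CC1)C(=O)O` remains to be measured. It differs from compound 1 by 3-aminopropyl in place of carbamoyl on a saturated chain carbon, two bonds along the chain from an amide-type nitrogen and a carbonyl carbon. Going by the values given here, no measured pair shows this change, so its size is unknown. With both known values low and close, the step of a number 1.9 percentage points higher from compound 1 to compound 3 (within the scatter) is expected to stay within the scatter. Compound 3 is therefore estimated at 22%, with a range from 8% to 40%.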

Compound 3, a percentage reported as activity, at one dose (the size of the read-out at that dose, not a potency): 28.8%
Compound 3: middle estimate off by 6.8 percentage points, on the low side; low and high end bracket the measured number.
By their numbers in this assay, from the lowest: compounds 1, 2 and 3 (each within the scatter of the next).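

In this assay, the swap of carbamoyl for 3-aminopropyl on this saturated chain carbon gives a number 8.7 percentage points higher from compound 1 to compound 3 (within the scatter). Going by these compounds alone, this is the first direct reading of a change at this position, and it shows that a longer chain ending in an amine cannot be told apart from carbamoyl here at the one dose given. Nothing measured here bears on why the two groups read alike.

Going by these compounds, whether a plain butyl chain without the amine or a guanidine at the chain end would read differently remains open. So does whether any group at this position can move the number beyond the scatter.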